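This account rests on a few compounds, and the source may have more. Where it says the series, first, only, none or still open, it means among the compounds named here.

In a functional assay on Bel-7402 cells (Homo sapiens) for inhibition, read by sulforhodamine B assay, with a stated time of 72 h (a higher number here means a weaker inhibitor, a lower number a stronger inhibitor), compound 1 `Cc1ccc2c(c1)c([C@H](C)Nc1ncnc3[nH]cnc13)nn2-c1cccnc1` gives > 40000 nM, which is a limit of the assay and not a number. Compound 2 `C[C@H](Nc1ncnc2[nH]cnc12)c1nn(-c2cccc(F)c2)c2cc(F)ccc12` gives > 40000 nM, which is also a limit. Going by the values given here, the evidence so far is the limit of > 40000 nM in this assay, at which 2 of the 2 values shown sit, and no measured step gives a size for any change. Compound 3 `C[C@H](Nc1ncnc2[nH]cnc12)c1nn(-c2cccc(S(C)(=O)=O)c2)c2cc(F)ccc12` differs from compound 2 by methylsulfonyl in place of fluoro on an aromatic carbon, with methylsulfonyl in place of fluoro on an aromatic carbon. In this assay the expected a number no higher from compound 2 to compound 3 (the limit leaves the size open) lies within the scatter, with no direction foreseen. For compound 3 the estimated value is 40000 nM, within an expected range of 20000 nM to 80000 nM.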

Compound 3, half-maximal inhibitory concentration: 20000 nM
Compound 3: the middle estimate sits 2.0-fold (0.30 log units) above what was measured; the range from low to high includes it.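

In this assay, going by these compounds alone, methylsulfonyl on this aromatic carbon, meta to a large group, gives the first value that is a number and not a limit: compound 3 gives 20000 nM. The change amounts to an at least 2.0-fold lower number from compound 2 to compound 3 (0.30 log units; that floor lies within the scatter), so the position accepts methylsulfonyl without loss of the read-out. Compound 2 remains a limit of the assay, which leaves the true size of the step open: the limit of > 40000 nM in this assay, at which 2 of the 3 values shown sit.

On these data alone, whether an amine or a carboxylic acid at this position would give a clearly lower number stays open. So does whether methylsulfonyl would act alike on the core of compound 1.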